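From 3-methoxyphenyl to 4-hydroxyphenyl at an assay limit

The compounds below may be only part of what the source reports. "The series", "measured", "known", "first", "only" and "open" are said of these compounds alone.

Measured so far in an ADME assay on Vero cells (Chlorocebus sabaeus) for antiproliferative activity, read by MTT assay, with a stated time of 72 h (on this read-out higher numbers stand for weaker inhibition and lower numbers for stronger inhibition), are these two compounds:
- Compound 1 `COc1cccc(N(C)S(=O)(=O)C2CC3OC2C(c2ccc(NC(=O)CCCCCCC(=O)O)cc2)=C3c2ccc(O)cc2)c1` gives > 100000 nM as a limit of the assay, not a number
- Compound 2 `CCN(c1cccc(OC)c1)S(=O)(=O)C1CC2OC1C(c1ccc(NC(=O)CCCCCCC(=O)O)cc1)=C2c1ccc(O)cc1` gives > 100000 nM as a limit of the assay, not a number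

Compound 2 therefore has no exact position, only a limit (the limit of > 100000 nM in this assay, at which 2 of the 2 values shown sit). Compound 3 `CCN(c1ccc(O)cc1)S(=O)(=O)C1CC2OC1C(c1ccc(NC(=O)CCCCCCC(=O)O)cc1)=C2c1ccc(O)cc1` carries 4-hydroxyphenyl in place of 3-methoxyphenyl on a sulfonamide nitrogen. Among the measured compounds shown here, the only measured step concerns a different group on that nitrogen, and its size cannot be read (a step that the two limits leave unreadable from compound 1 to compound 2). It offers no size to carry over, so no step beyond the usual scatter is expected in this assay on present evidence. The expected step is a number no higher from compound 2 to compound 3 (the limit leaves the size open) and rests on this absence of any readable change. Compound 3 is estimated at 100000 nM (expected range 30000 nM to 300000 nM).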

Compound 3, half-maximal inhibitory concentration: > 100000 nM
Compound 3: only a limit was reported; the forecaster's own chance of this, stated with the estimate: 85%; the middle value lies on the limit itself.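

No step can be read among compound 1, compound 2 and compound 3, as each value is a limit and not a number: the limit of > 100000 nM in this assay, at which 3 of the 3 values shown sit. Going by these compounds, whether 4-hydroxyphenyl in place of 3-methoxyphenyl on the sulfonamide nitrogen changes the inhibition at all stays open.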